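A Methyl Group Added to Compound 1

The source may hold more compounds than are shown below. What is called first, only, known or untested is meant among the compounds shown, and "the series" means these compounds.

In a functional assay on MT4 cells (Homo sapiens) for cytotoxicity (on this read-out lower numbers stand for stronger inhibition and higher numbers for weaker inhibition), compound 1 (`COc1cccc(Sc2cccc(N)c2C#N)c1`) gives > 200000 nM as its result, which is a limit and not a number. Compound 1 thus stands at the limit of > 200000 nM in this assay, at which 1 of the 3 values shown sits, and has no exact value.

Compound 4 (`COc1cc(C)cc(Sc2cccc(N)c2C#N)c1`) carries methyl in place of hydrogen on an aromatic carbon, meta to a methoxy group (methyl in place of hydrogen on an aromatic carbon). In this assay compound 2 (`N#Cc1c(N)cccc1Sc1cccc(Cl)c1`) gives 53000 nM as a number. In this assay compound 3 (`N#Cc1c(N)cccc1Sc1cccc(N)c1`) gives 168000 nM as a number.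

Among the measured compounds shown here, no measured step adds a methyl, so these steps bear on the change only loosely. With chloro the data show an at least 3.7-fold lower number from compound 1 to compound 2 (0.57 log units; beyond the scatter) while with amino they show an at least 1.1-fold lower number from compound 1 to compound 3 (0.07 log units; that floor lies within the scatter) and between those two they show a 3.2-fold higher number from compound 2 to compound 3 (0.50 log units; beyond the scatter) in this small set. Since even these exchanges are modest at most, only a small move toward a lower number is expected, possibly none beyond the scatter.

The expected change is an at least 1.3-fold lower number from compound 1 to compound 4 (0.12 log units; that floor lies within the scatter) by this estimate. For compound 4 the estimate is 150000 nM with a range from 60000 nM to 300000 nM as expected here.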

Compound 4, half-maximal inhibitory concentration: 10000 nM
Compound 4: middle estimate off by 15-fold (1.18 log units), on the high side, and the stated range ends above it.
By their numbers in this assay, from the lowest: compound 4; then compound 2; then compound 3. At a limit, above all of these: compound 1.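

In this assay, the added methyl gives an at least 20-fold lower number from compound 1 to compound 4 (1.30 log units; beyond the scatter), a large step. The earlier steps shown here all exchanged the methoxy group or what stood in its place, whereas this one leaves the methoxy group in place and shows that a carbon of the same ring, carrying only hydrogen in compound 1, also answers to a change, and that a single added carbon is enough. The value of compound 1 is a limit and not a number, so the size of this step is only a floor: the limit of > 200000 nM in this assay, at which 1 of the 4 values shown sits.

Going by these compounds, it remains open whether a longer chain such as ethyl, a hydroxyl group or a carboxylic acid at this same place would move the number in the same direction. Also open, on these data alone, is whether methyl there has a like effect when chloro or amino stands in place of the methoxy group, as in compound 2 and compound 3.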